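Cyclobutyl to methylcyclopropyl on the acyl group

The source may hold more compounds than are shown below. What is called first, only, known or untested is meant among the compounds shown, and "the series" means these compounds.

Within the data shown here, three amides of the shared core have numbers so far in an assay on CHO cells for displacement of a labelled ligand from Neuronal acetylcholine receptor; alpha3/alpha6/beta2/beta3 (Homo sapiens), read by scintillation counting; a higher number here means a weaker inhibitor, a lower number a stronger inhibitor. Compound 1 `O=C(C1CCC1)N1CC2CC(C1)N2` gives 240 nM, the lowest of the three. Compound 2 `O=C(C1CC=CC1)N1CC2CC(C1)N2` gives 1100 nM, and compound 3 `O=C(CC1C=CCC1)N1CC2CC(C1)N2` gives 2500 nM; both of these gaps from compound 1 are beyond the scatter, so compound 1 stands as the strongest inhibitor among the measured three. Among the measured compounds shown here, no step between two measured compounds that differ in one place alone is available, so the change to compound 4 has no direct precedent.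

Compound 4 `C[C@@H]1C[C@@H]1C(=O)N1CC2CC(C1)N2` differs from compound 1 as follows: a group of 4 heavy atoms (4 carbon; one three-membered non-aromatic ring of carbon only) in place of a group of 4 heavy atoms (4 carbon; one four-membered non-aromatic ring of carbon only), on a carbonyl carbon. The two have the same atoms, joined differently, and the change is confined to the ring on the carbonyl carbon. For the measured compounds named here, with no measured step to rest on, the expectation is a step of small size in this assay, or none beyond the scatter, in either direction. The estimate for compound 4 is 300 nM (range 100 nM to 900 nM), which is expected to mean a 1.3-fold higher number from compound 1 to compound 4 (0.10 log units; within the scatter).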

Compound 4, inhibition constant: 92 nM
Estimate against measurement, compound 4: 3.3-fold (0.51 log units) above; measured number below the stated range.
By their numbers in this assay, from the lowest: compound 4; then compound 1; then compound 2; then compound 3.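

In this assay, among these compounds, the ring on the carbonyl carbon responds to a change that keeps the same atoms, joined differently: the step is a 2.6-fold lower number from compound 1 to compound 4 (0.42 log units; beyond the scatter) and gives the first reading of a single change in one place. Cyclobutyl is therefore not the best of the groups shown at this position, as methylcyclopropyl with its 2 defined stereocentres gives the lower number. No measurement at hand accounts for this step.

The compounds shown give only one stereochemical form of methylcyclopropyl, so the contribution of its arrangement remains open. They also leave open whether the methyl group itself matters, which plain cyclopropyl would test, and how a larger ring such as cyclohexyl would read at this position.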